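A few compounds are considered here, and "the series" means these few. Any claim that something is new, unique, unknown or untested is made for them only; others in the source may bear on it.

Working notes on the series. In a functional assay on A549 cells (Homo sapiens) for antiproliferative activity, read by MTT assay, with a stated time of 48 h (a lower number here means a stronger inhibitor, a higher number a weaker inhibitor), compound 1 `Cc1ccc(/C=C/C(=O)Nc2nnc(-c3ccc(Cl)cc3)s2)cc1` gives 1.25 ug/mL, compound 2 `O=C(/C=C/c1ccc(C(F)(F)F)cc1)Nc1nnc(-c2ccc(Br)cc2)s1` gives 4.68 ug/mL and compound 3 `O=C(/C=C/c1ccc(C(F)(F)F)cc1)Nc1nnc(-c2ccccc2)s1` gives 1.78 ug/mL. Compound 3 therefore sits within the scatter of compound 1 and well under compound 2.

The next change leads to compound 4 `O=C(/C=C/c1ccc(C(F)(F)F)cc1)Nc1nnc(-c2ccc(Cl)cc2)s1`, with chloro in place of hydrogen on an aromatic carbon, para to a large group, turning phenyl into 4-chlorophenyl: chloro in place of hydrogen on an aromatic carbon.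

For the measured compounds named here, the one measured step that bears on this is a 2.6-fold lower number from compound 2 to compound 3 (0.42 log units; beyond the scatter). It is a modest step that exchanges bromo for hydrogen, so read in reverse it adds a different halogen at an aromatic carbon and goes to a higher number. Chloro is not bromo, so one step is only a rough guide, and a rise in the same direction but of smaller size is expected in this assay. It may not clear the scatter. Compound 4 shares the 4-chlorophenyl group with compound 1 at 1.25 ug/mL, but the two differ elsewhere, which tempers the expected rise and widens the range.

The estimated change is a 1.6-fold higher number from compound 3 to compound 4 (0.20 log units; within the scatter). For compound 4 the expected value is 2.8 ug/mL, with an estimated range from 1.3 ug/mL to 5.5 ug/mL.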

Compound 4, half-maximal inhibitory concentration: 3.09 ug/mL
The estimate for compound 4 lay 1.1-fold (0.04 log units) below the measured number; the measured number falls inside the stated range.
By their numbers in this assay, from the lowest: compounds 1, 3, 4 and 2 (each within the scatter of the next, the first and the last beyond it).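

With trifluoromethyl held constant, chloro does not clearly separate from either neighbouring substituent in this assay: the change from hydrogen gives a 1.7-fold higher number from compound 3 to compound 4 (0.24 log units; within the scatter) and the change from bromo gives a 1.5-fold lower number from compound 2 to compound 4 (0.18 log units; within the scatter), although hydrogen and bromo themselves differ beyond the scatter. This position therefore does not yet resolve chloro from hydrogen or from bromo, and the three compounds give no firm halogen order. For the compounds shown here, compound 4 also opens a second point of comparison, with 4-chlorophenyl held constant: trifluoromethyl in place of methyl gives a 2.5-fold higher number from compound 1 to compound 4 (0.39 log units; beyond the scatter), the only step at that site and a modest one. No measurement is available to explain any of these steps.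

The compounds shown leave open whether the methyl to trifluoromethyl step keeps its size with phenyl or 4-bromophenyl in place of 4-chlorophenyl. They also leave open whether a methoxy group or an amine on the aromatic carbon that carries the halogen would give a number clearly apart from those of the hydrogen, chloro and bromo compounds.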